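Chloro for fluoro on the outer ring of two cores

The source may hold more compounds than are shown below. What is called first, only, known or untested is meant among the compounds shown, and "the series" means these compounds.

Measured compounds in a functional assay on Jurkat cells (Homo sapiens) for activation, with a stated time of 24 h; a lower number here means that less compound is needed, a higher number that more compound is needed for the effect:
- compound 1, `Oc1ccccc1CNc1ccc(-c2cccc(F)c2)cc1`, gives 2020 nM
- compound 2, `Oc1ccccc1CNc1ccc(-c2cccc(Cl)c2)cc1`, gives 6200 nM
- compound 3, `Oc1ccccc1CNc1ccc(-c2ccc(F)cc2)nc1`, gives 2590 nM

Compound 4, `Oc1ccccc1CNc1ccc(-c2ccc(Cl)cc2)nc1`, has not yet been measured in this assay. It is related to compound 3 by one change, (chloro in place of fluoro on an aromatic carbon). The same kind of change, (chloro in place of fluoro on an aromatic carbon), connects compound 1 to compound 2, where it produced a 3.1-fold higher number from compound 1 to compound 2 (0.49 log units; beyond the scatter). The two occurrences are not identical in their surroundings: in the pair of compound 1 and compound 2 the exchanged atom sits meta to a large group, whereas in the pair of compound 3 and compound 4 it sits para to a large group. How the core of compound 3 differs from the core of compound 1 is not broken down here.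

Compound 3 and compound 1 give numbers within the usual scatter of each other in this assay, so the two cores start from a comparable level. Among the compounds with values here, with only one measured example of this exchange to rest on, the expectation for compound 4 in this assay is a step of about a 2.7-fold higher number from compound 3 to compound 4 (0.43 log units; beyond the scatter), taken from the size of a 3.1-fold higher number from compound 1 to compound 2 (0.49 log units; beyond the scatter) and applied to compound 3. Compound 4 is therefore estimated at 7000 nM, with a likely range from 2500 nM to 20000 nM.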

Compound 4, half-maximal effective concentration: "not active" (no number reported)
Compound 4: no number reported; the estimate stays without a comparison.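

In this assay, within the data shown here, compound 4 is reported as "not active" with no number, so no step from compound 3 to compound 4 can be read. The compounds shown leave open how far 4-fluorophenyl to 4-chlorophenyl moves the number on this core, and whether it matches the exchange between compound 1 and compound 2. Nothing available bears on why compound 4 gives this result.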